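The compounds below may be only part of what the source reports. "The series", "measured", "known", "first", "only" and "open" are said of these compounds alone.

The measured compounds, in a functional assay on HeLa cells (Homo sapiens) for antiproliferative activity, read by MTT assay, with a stated time of 48 h; a higher number here means a weaker inhibitor, a lower number a stronger inhibitor:

Compound 1 `FC(F)(F)c1ccc2[nH]c(-c3cn(-c4ccccc4)nc3-c3ccc(Cl)cc3)nc2c1` gives 4420 nM.
Compound 2 `Cc1ccc2[nH]c(-c3cn(-c4ccccc4)nc3-c3ccc(Cl)cc3)nc2c1` gives 5360 nM.
Compound 3 `COc1ccc(-c2nn(-c3ccccc3)cc2-c2nc3cc(C(F)(F)F)ccc3[nH]2)cc1` gives 2760 nM.

Compound 2 differs from compound 1 by methyl in place of trifluoromethyl on an aromatic carbon, and in this assay the step is a 1.2-fold higher number from compound 1 to compound 2 (0.08 log units; within the scatter). Compound 3 differs from compound 1 by methoxy in place of chloro on an aromatic carbon, and that step is a 1.6-fold lower number from compound 1 to compound 3 (0.20 log units; within the scatter). Compound 3 carries the lowest number of the three, but both of its gaps to compound 1 and compound 2 lie within the scatter, so no order among the three is claimed.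

Compound 4 `COc1ccc(-c2nn(-c3ccccc3)cc2-c2nc3cc(C)ccc3[nH]2)cc1` has not yet been measured. It differs from compound 3 by methyl in place of trifluoromethyl on an aromatic carbon. This is the same change as the one from compound 1 to compound 2, and it occurs twice among the compounds shown; the two places are described in identical words. The cores of compound 1 and compound 3 differ only in the way already told above for the pair of compound 1 and compound 3.

Since the change from compound 1 to compound 2 moved the number by a 1.2-fold higher number from compound 1 to compound 2 (0.08 log units; within the scatter), the step from compound 3 to compound 4 in this assay is expected to be of a similar small size, a 1.2-fold higher number from compound 3 to compound 4 (0.08 log units; within the scatter). Compound 4 is therefore estimated at 3300 nM. For compound 4 the expected range runs from 1500 nM to 7500 nM, resting on a single earlier instance of the change and on the value of compound 3, 2760 nM.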

Compound 4, half-maximal inhibitory concentration: 3290 nM
Beside the measured number, compound 4's estimate is 1.0-fold (0.00 log units) above it; low and high end bracket the measured number.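

In this assay, methyl in place of trifluoromethyl on the core that carries methoxy gives a 1.2-fold higher number from compound 3 to compound 4 (0.08 log units; within the scatter), which agrees with the same change on the core that carries chloro: the same change on two cores in this assay, a 1.2-fold higher number (0.08 log units; within the scatter) from compound 1 to compound 2 and a 1.2-fold higher number (0.08 log units; within the scatter) from compound 3 to compound 4, 1.0-fold (0.01 log units) apart, within the scatter of two such steps. Methoxy in place of chloro, read on the cores that carry methyl, gives a 1.6-fold lower number from compound 2 to compound 4 (0.21 log units; within the scatter), and this change also carries over from one core to the other: the same change on two cores in this assay, a 1.6-fold lower number (0.20 log units; within the scatter) from compound 1 to compound 3 and a 1.6-fold lower number (0.21 log units; within the scatter) from compound 2 to compound 4, 1.0-fold (0.01 log units) apart, within the scatter of two such steps. Together the four compounds show that each change gives a step of matching size on both cores, but every one of these steps lies within the scatter, so they do not show that either change truly moves the number, and the agreement amounts only to two small steps that cannot be told apart on two closely related cores.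

The compounds shown leave open whether a group of another kind on the same aromatic carbon, such as an amine, a carboxylic acid or a longer alkyl chain, would give a step beyond the scatter. They also leave open whether a step of that larger size would carry over between the core of compound 1 and the core of compound 3 as closely as these small ones do.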